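Swapping the Sulfur-Bound Tail of an Ester Side Chain

The compounds below may be only part of what the source reports. "The series", "measured", "known", "first", "only" and "open" are said of these compounds alone.

Compound 1 `C=C1CC[C@@H]2[C@](C)(CO)[C@H](O)CC[C@@]2(C)[C@@H]1CC(Sc1ccc([N+](=O)[O-])cc1)C1=CCOC1=O` gives 17000 nM in a functional assay on PC-3 cells (Homo sapiens) for inhibition, read by MTT assay, with a stated time of 48 h; a higher number here means a weaker inhibitor, a lower number a stronger inhibitor.
Compound 2 `C=C1CC[C@@H]2[C@](C)(CO)[C@H](O)CC[C@@]2(C)[C@@H]1CC(Sc1nccs1)C1=CCOC1=O` gives 14000 nM in this assay.
Compound 3 `C=C1CC[C@@H]2[C@](C)(CO)[C@H](O)CC[C@@]2(C)[C@@H]1C/C=C1/C(=O)OC[C@H]1OC(=O)CSc1ccc([N+](=O)[O-])cc1` gives 17000 nM in this assay.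

Compound 3 stands level with compound 1, and the two together hold the highest numbers of the three; compound 2 sits within the scatter of both. Compound 4 `C=C1CC[C@@H]2[C@](C)(CO)[C@H](O)CC[C@@]2(C)[C@@H]1C/C=C1/C(=O)OC[C@H]1OC(=O)CCCSc1ccc(C)cc1` differs from compound 3 by 2-((4-methylphenyl)sulfanyl)ethyl in place of (4-nitrophenyl)sulfanyl on a saturated chain carbon bound to a carbonyl carbon. For the measured compounds named here, the only measured step, a 1.2-fold lower number from compound 1 to compound 2 (0.08 log units; within the scatter), changes a group on a sulfur in a different part of the molecule and stays within the scatter, so it gives no sign that the sulfur-bound tail moves the number. The step from compound 3 to compound 4 is therefore expected to be small, a 1.1-fold lower number from compound 3 to compound 4 (0.05 log units; within the scatter), with no clear direction. Compound 4 is estimated at 15000 nM, within 6000 nM to 40000 nM.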

Compound 4, half-maximal inhibitory concentration: 16000 nM
Compound 4: the middle estimate sits 1.1-fold (0.03 log units) below what was measured; measured number inside the range.
By their numbers in this assay, from the lowest: compounds 2, 4, 1 and 3 (each within the scatter of the next).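

At this place, on a saturated chain carbon bound to a carbonyl carbon, 2-((4-methylphenyl)sulfanyl)ethyl in place of (4-nitrophenyl)sulfanyl gives a 1.1-fold lower number from compound 3 to compound 4 (0.03 log units; within the scatter) in this assay as the result. So this side of the molecule tolerates a swap from 3 hydrogen-bond acceptors to 1, with the nitrogen and oxygen atoms gone and the aromatic ring kept, without a step beyond the scatter. Nothing measured here explains why the number stays level.
Going by these compounds, whether an amine or a carboxylic acid on this chain would move the number remains open. So does a tail with no aromatic ring.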